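Swapping Methyl for Trifluoromethyl in an Inactive Series

A few compounds are considered here, and "the series" means these few. Any claim that something is new, unique, unknown or untested is made for them only; others in the source may bear on it.

In a functional assay on MCF7 cells (Homo sapiens) for antiproliferative activity, with a stated time of 96 h (a lower number here means a stronger inhibitor, a higher number a weaker inhibitor), compound 1 (`Cc1cc(=O)oc2cc(OCC(=O)c3ccc(C(F)(F)F)cc3)ccc12`) gives > 100000 nM as a limit of the assay and not a number. In this assay compound 2 (`Cc1ccc(C(=O)COc2ccc3c(C(F)(F)F)cc(=O)oc3c2)cc1`) is reported as "not active" (no number reported) with no number attached, so no single value fixes its place on the scale. Compound 3 (`O=C(COc1ccc2c(C(F)(F)F)cc(=O)oc2c1)c1ccc(C(F)(F)F)cc1`) has yet to be measured in this assay and follows from compound 2 through one structural change. That change is trifluoromethyl in place of methyl on an aromatic carbon and amounts to trifluoromethyl in place of methyl on an aromatic carbon, para to a large group. Among the measured compounds shown here, no step between measured compounds is available to gauge the size of such a change. A step beyond the scatter is not expected in this assay in either direction, and this expectation rests on compound 2 with its reading of "not active" (no number reported) as the starting point. In this assay compound 3 is estimated at 100000 nM within an expected range of 30000 nM to 200000 nM.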

Compound 3, half-maximal inhibitory concentration: "not active" (no number reported)
The entry for compound 3 holds no number, and the estimate cannot be compared.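

In this assay, among the compounds shown here, compound 2 and compound 3 are both reported as "not active" with no number attached, so no step between them can be read. The compounds shown leave open how far any of them lies from a measurable antiproliferative effect, and the only figure they offer on the scale is this: the limit of > 100000 nM in this assay, at which 1 of the 3 values shown sits.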